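Replacing pyridin-3-yl with 4-cyanophenyl on an aromatic nitrogen

The compounds below may be only part of what the source reports. "The series", "measured", "known", "first", "only" and "open" are said of these compounds alone.

- compound 1 `C[C@H](Nc1ncnc2[nH]cnc12)c1nn(-c2cccc(F)c2)c2cc(F)ccc12`: > 40000 nM (a limit)
- compound 2 `C[C@H](Nc1ncnc2[nH]cnc12)c1nn(-c2cccnc2)c2cc(F)ccc12`: 34500 nM

Within the data shown here, in a functional assay on Hep 3B2 cells (Homo sapiens) for inhibition, read by sulforhodamine B assay, with a stated time of 72 h (on this read-out lower numbers stand for stronger inhibition and higher numbers for weaker inhibition), compound 2 gives 34500 nM, the only actual number in this small set. Compound 1 gives only a limit, > 40000 nM. The second value therefore has just a limit to be read against: the limit of > 40000 nM in this assay, at which 1 of the 2 values shown sits.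

The next structure is compound 3 `C[C@H](Nc1ncnc2[nH]cnc12)c1nn(-c2ccc(C#N)cc2)c2cc(F)ccc12`, with 4-cyanophenyl in place of pyridin-3-yl on an aromatic nitrogen.

Among the measured compounds shown here, one measured step bears on this place, an at least 1.1-fold lower number from compound 1 to compound 2 (0.06 log units; that floor lies within the scatter). It shows no change beyond the scatter, and it is bounded on one side only. No clear step is therefore expected in this assay, in either direction, and compound 3 may also end at the limit. The expected change is a 1.0-fold higher number from compound 2 to compound 3 (0.01 log units; within the scatter). Compound 3 is expected at 35000 nM, with an estimated range from 14000 nM to 50000 nM.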

Compound 3, half-maximal inhibitory concentration: 13500 nM
The estimate for compound 3 lay 2.6-fold (0.41 log units) above the measured number; the measured number lies below the stated range.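

Among these compounds, this position is not silent in this assay: the change to 4-cyanophenyl gives the first step beyond the scatter (a 2.6-fold lower number from compound 2 to compound 3 (0.41 log units; beyond the scatter)), where the earlier step between 3-fluorophenyl and pyridin-3-yl showed none. The same group also separates from 3-fluorophenyl (an at least 2.9-fold lower number from compound 1 to compound 3 (0.47 log units; beyond the scatter)), which leaves compound 3 with the lowest number of the three, although the step is modest. The value of compound 1 is a limit, so the second step has a floor only: the limit of > 40000 nM in this assay, at which 1 of the 3 values shown sits.

Going by these compounds, whether the gain depends on the nitrile itself remains open, since no plain phenyl, primary amide, carboxylic acid or amine on that ring stands beside it. How far the trend runs on this aromatic nitrogen also remains open, with three compounds and a single cell assay shown.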